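The source may report more compounds than this note shows. Statements on the series, on what has been measured and on what is new or still open speak of the compounds shown alone.

In a functional assay on MT2 cells (Homo sapiens) for cytotoxicity, read by MTT assay (a lower number here means that less compound is tolerated, a higher number that more compound is tolerated), compound 1 (`CC(C)=CCOc1cc(Nc2nccs2)ccc1C(C)C`) gives 31000 nM and compound 2 (`Clc1ccc(Nc2nccs2)cc1OCc1ccoc1`) gives 26000 nM as its value. Compound 2 thus stands within the usual scatter of compound 1, and the two structures differ in more than one place. Next in the series is compound 3 (`Clc1ccc(Nc2nccs2)cc1OCc1ccsc1`), with thiophen-3-yl in place of furan-3-yl on a saturated chain carbon bound to an oxygen on an aromatic ring. Within the data shown here, no measured step speaks to this exchange, so the expectation rests on the structural change alone, which is confined to the hetero atom of the ring, oxygen leaving and sulfur entering. No step beyond the scatter is expected in this assay and no direction is favoured. The estimate means a step (a 1.0-fold lower number from compound 2 to compound 3 (0.02 log units; within the scatter)) within that scatter. For compound 3 the estimated value is 25000 nM with an expected range from 12000 nM to 50000 nM around it.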

Compound 3, half-maximal cytotoxic concentration: 38000 nM
Compound 3: the middle estimate sits 1.5-fold (0.18 log units) below what was measured; measured number inside the range.
By their numbers in this assay, from the lowest: compounds 2, 1 and 3 (each within the scatter of the next).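

In this assay, among these compounds, thiophen-3-yl in place of furan-3-yl on a saturated chain carbon bound to an oxygen on an aromatic ring gives the first single-place step (a 1.5-fold higher number from compound 2 to compound 3 (0.16 log units; within the scatter)). At this position, on this one pair, oxygen leaving the ring and sulfur entering it does not shift the reading beyond the scatter, so the two rings cannot be told apart by this read-out. Nothing at hand bears on the reason for this result.

Still open, on these data alone, is whether a larger change at this place, such as a phenyl ring, a pyridin-3-yl ring or a chain ending in an amine, would produce a step beyond the scatter. Also open, as far as these compounds go, is whether the same ring exchange reads alike on the core of compound 1.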